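The compounds below may be only part of what the source reports. "The series", "measured", "known", "first", "only" and "open" are said of these compounds alone.

Compound 1 `CCOc1cc2ncnc(Nc3ccc(F)c(Cl)c3)c2cc1OC(=O)CSc1ccccn1`: in a functional assay on NCI-H1975 cells (Homo sapiens) for inhibition, read by MTT assay, with a stated time of 72 h (on this read-out higher numbers stand for weaker inhibition and lower numbers for stronger inhibition), compound 1 gives 3700 nM.
Compound 2 `CCOc1cc2ncnc(Nc3ccc(F)c(Cl)c3)c2cc1OC(=O)CSc1ncccn1`: in this assay compound 2 gives 3600 nM.
Compound 3 `CCOc1cc2ncnc(Nc3ccc(F)c(Cl)c3)c2cc1NC(=O)COC(C)=O`: in this assay compound 3 gives 3400 nM.

The three measured compounds share one core and differ only in the group on one aromatic carbon. Compound 3 sits level with the other two: the steps of a 1.1-fold lower number from compound 1 to compound 3 (0.04 log units; within the scatter) and a 1.1-fold lower number from compound 2 to compound 3 (0.02 log units; within the scatter) are both within the scatter, so the exchange of the whole side chain at that aromatic carbon, ester for amide and thioether-bearing ring for acetoxy, left the read-out essentially unchanged. Likewise a 1.0-fold lower number from compound 1 to compound 2 (0.01 log units; within the scatter), the swap of one ring for another on the sulfur, made no difference beyond the scatter.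

Compound 4 `CCOc1cc2ncnc(Nc3ccc(F)c(Cl)c3)c2cc1NC(=O)COC(=O)c1ccccc1` differs from compound 3 by phenyl in place of methyl on a carbonyl carbon. Among the compounds with values here, no measured step touches this carbonyl carbon, so there is no direct precedent. What the record does show is that far larger changes in this side chain, as in a 1.1-fold lower number from compound 1 to compound 3 (0.04 log units; within the scatter) and a 1.1-fold lower number from compound 2 to compound 3 (0.02 log units; within the scatter), produced no step beyond the scatter. On that basis the step of no change at the digits printed from compound 3 to compound 4 (within the scatter) is expected to stay within the scatter in either direction. Compound 4 is therefore estimated at 3400 nM, with a range from 1700 nM to 7000 nM.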

Compound 4, half-maximal inhibitory concentration: 8300 nM
Compound 4: the middle estimate sits 2.4-fold (0.39 log units) below what was measured; measured number above the stated range.
By their numbers in this assay, from the lowest: compounds 3, 2 and 1 (each within the scatter of the next); then compound 4.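

In this assay the step of a 2.4-fold higher number from compound 3 to compound 4 (0.39 log units; beyond the scatter) is the only one shown that passes beyond the scatter, and it is modest in size. It shows that this side chain does not tolerate every change: phenyl in place of methyl on the carbonyl carbon gives weaker inhibition, although the much larger exchanges that link compound 1, compound 2 and compound 3 left the numbers level. Nothing available here bears on why this exchange has that effect.

The compounds shown leave open whether the weaker inhibition belongs to the aromatic ring itself or simply goes with the larger number of carbons that enter with it, a question that a cyclohexyl or a benzyl on the same carbonyl carbon would address. Within the data shown here, it also remains open whether the single methyl-to-phenyl pair marks a wider trend at this carbonyl carbon, and whether an aminomethyl group or a carboxylic acid there would bring the number back toward that of compound 3 or take it further away.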